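The compounds below may be only part of what the source reports. "The series", "measured", "known", "first", "only" and "open" are said of these compounds alone.

Compound 3 `O=C(NCCCCc1ccccc1)n1cc(-c2cccnc2)oc1=O` gives 70 nM in an assay on isolated protein for inhibition of acid ceramidase (Homo sapiens), read by LC-MS, with a stated time of 1 h; on this read-out higher numbers stand for weaker inhibition and lower numbers for stronger inhibition. Compound 1 `COc1cccc(-c2cn(C(=O)NCCCCc3ccccc3)c(=O)o2)c1` gives 341 nM, and compound 2 `COc1cc(-c2cn(C(=O)NCCCCc3ccccc3)c(=O)o2)ccc1F` gives 80 nM in this assay. Compound 3 has the lowest of the three numbers: the step of a 4.9-fold lower number from compound 1 to compound 3 (0.69 log units; beyond the scatter) lies beyond the scatter, whereas compound 2 and compound 3 lie within the scatter of each other. Compound 4 `O=C(NCCCCc1ccccc1)n1cc(-c2ccncc2)oc1=O` differs from compound 3 by pyridin-4-yl in place of pyridin-3-yl on an aromatic carbon. For the measured compounds named here, no measured step exchanges one pyridinyl for another; the closest comparisons, a 4.9-fold lower number from compound 1 to compound 3 (0.69 log units; beyond the scatter) and a 4.3-fold lower number from compound 1 to compound 2 (0.63 log units; beyond the scatter), replaced or decorated a different ring, so they offer only indirect guidance and no step beyond the scatter is expected. Compound 4 is therefore estimated to give about 100 nM, with a range from 40 nM to 280 nM. The step expected is a 1.4-fold higher number from compound 3 to compound 4 (0.15 log units; within the scatter).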

Compound 4, half-maximal inhibitory concentration: 18 nM
Estimate against measurement, compound 4: 5.6-fold (0.74 log units) above; measured number outside the range, below it.
By their numbers in this assay, from the lowest: compound 4; then compounds 3 and 2 (each within the scatter of the next); then compound 1.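

Exchanging pyridin-3-yl for pyridin-4-yl keeps the same atoms and the same donor and acceptor counts, yet this assay shows a 3.9-fold lower number from compound 3 to compound 4 (0.59 log units; beyond the scatter), so at this position the place of the ring nitrogen matters, not only its presence. The pyridin-4-yl group also beats both substituted phenyl groups, with a 4.4-fold lower number from compound 2 to compound 4 (0.65 log units; beyond the scatter) and a 19-fold lower number from compound 1 to compound 4 (1.28 log units; beyond the scatter). Nothing available explains why this change has such an effect. As far as these compounds go, whether a pyridin-2-yl group or a pyrimidinyl ring here would give a lower or a higher number remains open.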